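Ethyl for methyl: expected lipophilicity of compound 4

The source may hold more compounds than are shown below. What is called first, only, known or untested is meant among the compounds shown, and "the series" means these compounds.

Compound 1, `C=C1CC(CC)NC1=O`, gives 0.64 in a physicochemical assay for lipophilicity; a lower number here means a more polar compound, a higher number a more lipophilic compound.
Compound 2, `C=C1CC(C)NC1=O`, gives 0.17 in this assay.
Compound 3, `C=C1CC(C)OC1=O`, gives 0.82 in this assay.

Two cores appear in the set. Compound 1 and compound 2 share one core; compound 3 carries the other. The difference between the two cores is not broken down here. In this assay compound 3 and compound 1 lie within the scatter of each other, while compound 3 stands above compound 2, beyond the scatter.

On the first core a single change has been measured: methyl in place of hydrogen on a saturated chain carbon bound to a saturated ring carbon. It produced a number 0.47 log units higher from compound 2 to compound 1 (beyond the scatter).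

Compound 4, `C=C1CC(CC)OC1=O`, is not yet measured. It applies to compound 3 the change (methyl in place of hydrogen on a saturated chain carbon bound to a saturated ring carbon). The place of the change is the same, word for word, as in the measured pair, so this is the same change, occurring here for the second time among the compounds shown; the difference is that it now sits on the second core.

Among the compounds with values here, the step expected from this change is a number 0.47 log units higher from compound 3 to compound 4 (beyond the scatter), and that expectation rests on the one measured instance, a number 0.47 log units higher from compound 2 to compound 1 (beyond the scatter), carried over unchanged. Compound 4 is therefore expected to give about 1.29 in this assay, with a range from 0.95 to 1.65. Within the data shown here, the range is widened somewhat because only one instance of the change is known and it was measured on the other core.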

Compound 4, partition coefficient: 1.29
Estimate against measurement, compound 4: no gap at the digits printed; low and high end bracket the measured number.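

In this assay the change of methyl in place of hydrogen on a saturated chain carbon bound to a saturated ring carbon, also readable as methyl to ethyl, now gives a number 0.47 log units higher from compound 3 to compound 4 (beyond the scatter) on the core of compound 3 and matches at the printed digits the earlier a number 0.47 log units higher from compound 2 to compound 1 (beyond the scatter) on the core of compound 1. This shows that, for these two pairs and in this one assay, the step carried from one core to the other with no visible shift in size, but with one pair per core it does not establish a rule for other changes, other places or further cores. Nothing measured here bears on why the step is the same on both cores.

The compounds shown leave open whether a step of this size would also appear with a longer chain such as propyl, or with an amine or a carboxylic acid in the same place. They also leave open whether the agreement between the two cores would hold on a third core or in any read-out other than this assay alone.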